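Moving the methoxyphenyl group on two related cores

A few compounds are considered here, and "the series" means these few. Any claim that something is new, unique, unknown or untested is made for them only; others in the source may bear on it.

Measured in a functional assay on P338 cells (Mus musculus) for antiproliferative activity; on this read-out higher numbers stand for weaker inhibition and lower numbers for stronger inhibition:
- compound 1 `COc1ccc(/C=C/C(=O)c2ccc(OCCn3cc(CN4C(=O)/C=C/C(C)(C)C/C=C(\C)CC/C=C/4C)nn3)cc2O)cc1` gives 1.21 ug/mL
- compound 2 `COc1cccc(/C=C/C(=O)c2ccc(OCCn3cc(CN4C(=O)/C=C/C(C)(C)C/C=C(\C)CC/C=C/4C)nn3)cc2O)c1` gives 0.89 ug/mL
- compound 3 `COc1ccc(/C=C/C(=O)c2ccc(OCCCN3C(=O)/C=C/C(C)(C)C/C=C(\C)CC/C=C/3C)cc2)cc1` gives 1.3 ug/mL

Compound 1 and compound 2 share one core and differ only in one place: 3-methoxyphenyl in place of 4-methoxyphenyl on a double-bonded chain carbon bound to a double-bonded chain carbon. On this change the read-out moved by a 1.4-fold lower number from compound 1 to compound 2 (0.13 log units; within the scatter), a step that sits inside the usual spread of repeated measurements, so the two compounds cannot be told apart on this evidence.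

Compound 3 carries a different core; how the core of compound 3 differs from the core of compound 1 is not broken down here. Its value is close to those of compound 1 and compound 2, all three lying within the scatter of one another, so no order among them can be claimed.

Compound 4 `COc1cccc(/C=C/C(=O)c2ccc(OCCCN3C(=O)/C=C/C(C)(C)C/C=C(\C)CC/C=C/3C)cc2)c1` is not yet measured. It stands to compound 3 exactly as compound 2 stands to compound 1: 3-methoxyphenyl in place of 4-methoxyphenyl on a double-bonded chain carbon bound to a double-bonded chain carbon. The place of the change is described in the same words for both pairs, so this is the same change on a second core.

For compound 4 the expected step is a 1.4-fold lower number from compound 3 to compound 4 (0.14 log units; within the scatter). For the measured compounds named here, this expectation rests on the step of a 1.4-fold lower number from compound 1 to compound 2 (0.13 log units; within the scatter), the only measured instance of this change, which stayed within the scatter. Compound 4 is therefore estimated at 0.95 ug/mL, with a likely range from 0.5 ug/mL to 1.9 ug/mL. Going by these compounds, whether the change behaves alike on both cores is untested; only these few compounds are available.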

Compound 4, half-maximal inhibitory concentration: 1.1 ug/mL
For compound 4 the middle estimate is 1.2-fold (0.06 log units) below the measured one; the measured number falls inside the stated range.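

In this assay, putting 3-methoxyphenyl in place of 4-methoxyphenyl on the second core gives a 1.2-fold lower number from compound 3 to compound 4 (0.07 log units; within the scatter), a step that again lies inside the usual spread of repeated measurements. Set beside the earlier step, it cannot be told apart from it: the same change on two cores in this assay, a 1.4-fold lower number (0.13 log units; within the scatter) from compound 1 to compound 2 and a 1.2-fold lower number (0.07 log units; within the scatter) from compound 3 to compound 4, 1.2-fold (0.06 log units) apart, within the scatter of two such steps. This shows that, on these two cores, the change from 4-methoxyphenyl to 3-methoxyphenyl leaves the read-out within the scatter, so knowing the result on one core would have been a fair guide to the result on the other; it does not show that the 3-methoxyphenyl compounds are truly the stronger inhibitors, since neither step can be told from no difference at all, and two pairs of compounds make no rule for the wider series.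

Going by these compounds, what stays open is whether a group of a different kind on the phenyl ring in place of the methoxy group, such as an amine, a carboxylic acid or a longer chain, would produce a step clearly beyond the scatter. On these data alone, it is also open whether a step of that larger size would carry from one core to the other as closely as this small one did.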